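A few compounds are considered here, and "the series" means these few. Any claim that something is new, unique, unknown or untested is made for them only; others in the source may bear on it.

Going by the values given here, in an ADME assay on microsomes from liver (Homo sapiens) for metabolic stability, read by LC-MS, using NADPH, with stated times of 5 min and 30 min, tested at 1 uM (on this read-out higher numbers stand for a more stable compound and lower numbers for a less stable compound), compound 1 `COc1cccc(S(=O)(=O)/C=C/c2ccccn2)c1` gives 74%, the higher of the two numbers known so far, while compound 2 `COc1cccc(S(=O)(=O)/C=C/c2cccc(Cl)n2)c1` gives 34%. Compound 3 `COc1cccc(S(=O)(=O)/C=C/c2ccncc2)c1` differs from compound 1 by pyridin-4-yl in place of pyridin-2-yl on a double-bonded chain carbon bound to a double-bonded chain carbon, with pyridin-4-yl in place of pyridin-2-yl on a double-bonded chain carbon bound to a double-bonded chain carbon. Among the compounds with values here, no measured step makes this exact change. The nearest guide is a large one, a number 40 percentage points lower from compound 1 to compound 2 (beyond the scatter), with chloro in place of hydrogen on an aromatic carbon. A smaller fall is therefore expected, estimated as a number 14 percentage points lower from compound 1 to compound 3 (beyond the scatter). Compound 3 is expected to give 60%, with an estimated range of 35% to 85%.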

Compound 3, percent of the compound remaining: 72%
Compound 3: the middle estimate sits 12 percentage points below what was measured; low and high end bracket the measured number.
By their numbers in this assay, from the lowest: compound 2; then compounds 3 and 1 (each within the scatter of the next).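

In this assay, pyridin-4-yl in place of pyridin-2-yl on a double-bonded chain carbon gives a number 2 percentage points lower from compound 1 to compound 3 (within the scatter). So the place where the pyridine ring is attached to the chain can change without a difference that stands out from the scatter, whereas the earlier chloro step was large. No available evidence bears on this result. Going by these compounds, what a plain phenyl ring or pyridin-3-yl would give at this place remains open. So does whether chloro on pyridin-4-yl would bring a fall like the one seen on pyridin-2-yl.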